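The compounds below may be only part of what the source reports. "The series", "measured", "known", "first", "only" and "open" are said of these compounds alone.

Compound 3 (`COC(=O)CNC(=O)c1ccc(Oc2nc3ccccc3nc2NC(C)(C)C)cc1`) reaches only a limit in a functional assay on K562 cells (Homo sapiens) for antiproliferative activity, read by MTT assay, with a stated time of 48 h (a lower number here means a stronger inhibitor, a higher number a weaker inhibitor), at > 50000 nM, so it has no exact number. Compound 4 (`CC[C@@H](C)[C@H](NC(=O)c1ccc(Oc2nc3ccccc3nc2NC(C)(C)C)cc1)C(=O)O`) has not yet been measured. It differs from compound 3 at one place: 1-carboxy-2-methylbutyl in place of (methoxycarbonyl)methyl on an amide-type nitrogen. In words, 1-carboxy-2-methylbutyl stands in place of (methoxycarbonyl)methyl on an amide-type nitrogen.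

The nearest measured comparison comes from a pair with a different core from compound 3. In this assay, compound 1 (`COC(=O)[C@H](CC(C)C)NC(=O)c1ccc(Oc2nc3ccccc3nc2C)cc1`) gives 22600 nM, and compound 2 (`Cc1nc2ccccc2nc1Oc1ccc(C(=O)N[C@@H](CC(C)C)C(=O)O)cc1`) gives 19500 nM. Within this pair, hydrogen takes the place of methyl on the oxygen, which turns a methyl ester into a free carboxy group. Compound 4 carries a carboxy group too, but the swap is expected to matter little because a 1.2-fold lower number from compound 1 to compound 2 (0.06 log units; within the scatter) is all that it produced in that pair. Going by the values given here, no measured step bears on the rest of the change, the longer branched chain. No clear shift is therefore expected in this assay, and compound 4 should stay weak, close to the limit of the assay. The estimated change is an at least 1.1-fold lower number from compound 3 to compound 4 (0.07 log units; that floor lies within the scatter). For compound 4 the expected value is 42000 nM, with an estimated range from 18000 nM to 90000 nM.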

Compound 4, half-maximal inhibitory concentration: 18300 nM
The estimate for compound 4 lay 2.3-fold (0.36 log units) above the measured number, and the stated range covers the measured number.
By their numbers in this assay, from the lowest: compounds 4, 2 and 1 (each within the scatter of the next). At a limit, above all of these: compound 3.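

In this assay, placing 1-carboxy-2-methylbutyl where (methoxycarbonyl)methyl stood on the amide-type nitrogen gives an at least 2.7-fold lower number from compound 3 to compound 4 (0.43 log units; beyond the scatter). The earlier pair, which has a different core, showed only a swap of methyl ester for free carboxy group at this part of the molecule, and that gave a 1.2-fold lower number from compound 1 to compound 2 (0.06 log units; within the scatter); the new step shows that a larger change on this nitrogen, made on the core of compound 3, can move the number beyond the scatter. Compound 3 stands at a limit of the assay rather than at an exact number, so the step is only a floor and its true size remains unknown: the limit of > 50000 nM in this assay, at which 1 of the 4 values shown sits.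

The new group differs from the old one in two ways at once, a free carboxy group instead of a methyl ester and a longer branched chain with defined stereocentres, and the compounds shown do not tell which of these goes with the step. A carboxymethyl group on that nitrogen, or the methyl ester of the 1-carboxy-2-methylbutyl group, would separate the two parts on this core.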